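Mirror-image pair in the monkey oral exposure series

This account rests on a few compounds, and the source may have more. Where it says the series, first, only, none or still open, it means among the compounds named here.

Among the compounds with values here, compound 2 `CS(=O)(=O)Nc1ccc2c(c1)S(=O)(=O)N=C(C1=C(O)[C@H]3CCCC[C@H]3N(Cc3ccc(F)cc3)C1=O)N2` gives 2910 ng.h/mL in an ADME assay on the whole organism (plasma) for pharmacokinetics, with Cynomolgus monkey (Macaca fascicularis) as the target, at a dose of 1 mg/kg by the oral route (a higher number here means more compound in the circulation at the dose given, a lower number less compound in the circulation), the higher of the two numbers so far; compound 1 `CS(=O)(=O)Nc1ccc2c(c1)S(=O)(=O)N=C(c1c(O)c3cccn3n(Cc3ccc(F)cc3)c1=O)N2`, at 6 ng.h/mL in this assay, lies beyond the scatter below it. Compound 3 `CS(=O)(=O)Nc1ccc2c(c1)S(=O)(=O)N=C(C1=C(O)[C@@H]3CCCC[C@@H]3N(Cc3ccc(F)cc3)C1=O)N2` is the mirror image of compound 2: the two compounds have the same atoms and bonds and differ only in configuration as drawn: 2 of 2 stereo elements differ (all stereocentres are inverted: mirror images); a stereocentre at a saturated ring carbon is drawn S in compound 2 and R in compound 3; a stereocentre at a saturated ring carbon is drawn R in compound 2 and S in compound 3. Within the data shown here, no measured pair differs in this way, so inversion of both stereocentres has no precedent in this assay; a moderate shift, most likely downward but possibly none beyond the scatter, is expected. For compound 3 the estimate is 1500 ng.h/mL, with a range of 300 ng.h/mL to 4500 ng.h/mL. The expected step is a 1.9-fold lower number from compound 2 to compound 3 (0.29 log units; within the scatter).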

Compound 3, area under the concentration-time curve: 610 ng.h/mL
Beside the measured number, compound 3's estimate is 2.5-fold (0.39 log units) above it; low and high end bracket the measured number.
By their numbers in this assay, from the lowest: compound 1; then compound 3; then compound 2.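

In this assay, inverting both stereocentres at the saturated ring carbons gives a 4.8-fold lower number from compound 2 to compound 3 (0.68 log units; beyond the scatter). Within the data shown here, this is the first measured step that isolates configuration, and the mirror-image relationship leaves nothing else to account for it. The shift can be assigned to configuration alone because no atom or bond changes: the fact that compounds 2 and 3 differ only in the configuration as drawn

Which of the two stereocentres carries the step remains open, as does the route by which configuration alters exposure. Also open, going by these compounds, is whether a hydroxyl group on the saturated ring would preserve the exposure of compound 2.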